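Cytotoxicity notes on the methoxy step to compound 3

The source may hold more compounds than are shown below. What is called first, only, known or untested is meant among the compounds shown, and "the series" means these compounds.

The series shares one core carrying the same side chain, seen in compound 1 `CSc1nc(Cl)c2ccn(COCCO)c2n1` and compound 2 `Nc1ncnc2c1ccn2COCCO`. In a functional assay on BSC-1 cells (Cercopithecidae) for cytotoxicity (on this read-out lower numbers stand for stronger inhibition and higher numbers for weaker inhibition), compound 1 gives > 100000 nM, which is a limit of the assay and not a number. In this assay compound 2 gives > 100000 nM, again a limit rather than a number. Compound 2 therefore has no place on a scale of numbers and stands at the limit of > 100000 nM in this assay, at which 2 of the 2 values shown sit. Compound 3 `COc1nc(N)c2ccn(COCCO)c2n1` is the next member; it differs from compound 2 by methoxy in place of hydrogen on an aromatic carbon. Among the measured compounds shown here, no measured step between two compounds exists, and with both known values at the limit no direction can be read from them. The step expected from this change, a number no higher from compound 2 to compound 3 (the limit leaves the size open), is none beyond the scatter. Compound 3 is estimated at 100000 nM in this assay, between 30000 nM and 300000 nM, and is expected most likely to be reported once more as a limit.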

Compound 3, half-maximal inhibitory concentration: > 100000 nM
Compound 3 was reported as a limit; the forecaster's own chance of this, stated with the estimate: 85%; the middle value lies on the limit itself.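

In this assay compound 3 gives > 100000 nM, a limit of the assay and not a number. Compound 2 also sits at a limit, so no step can be read from compound 2 to compound 3. The compounds shown leave open whether methoxy in place of hydrogen changes cytotoxicity at all.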